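Cytotoxicity notes: from compound 3 to compound 4

A few compounds are considered here, and "the series" means these few. Any claim that something is new, unique, unknown or untested is made for them only; others in the source may bear on it.

Measured compounds:
compound 1, `CCc1ccc(-c2nc3c(c(C)nn3-c3ccccc3)c(-c3ccc(O)cc3)c2C#N)cc1`: > 20000 nM
compound 2, `CCc1ccc(-c2nc3c(c(C)nn3-c3ccccc3)c(-c3ccccc3C(=O)OC)c2C#N)cc1`: > 20000 nM
compound 3, `Cc1ccc(-c2nc3c(c(C)nn3-c3ccccc3)c(-c3ccccc3O)c2C#N)cc1`: 22200 nM

In an ADME assay on BJ cells (Homo sapiens) for cytotoxicity, with a stated time of 72 h (on this read-out higher numbers stand for an effect only at larger amounts of compound and lower numbers for an effect already at smaller amounts), compound 1 reaches only a limit, not a number. Compound 2 likewise gives only a limit in this assay. Within the data shown here, compound 3 is the one compound with a number in this assay, and it sits close to the limit of > 20000 nM in this assay, at which 2 of the 3 values shown sit. Among the measured compounds shown here, the step that the two limits leave unreadable from compound 1 to compound 2 cannot be read for size, so no measured step gives a usable size for this series.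

Compound 4, `Cc1nn(-c2ccccc2)c2nc(-c3ccc4c(c3)CCCC4)c(C#N)c(-c3ccccc3O)c12`, is not yet measured. Its change from compound 3 is 1,2,3,4-tetrahydronaphthalen-6-yl in place of 4-methylphenyl on an aromatic carbon. For the measured compounds named here, no measured step touches a comparable change, and the only readable step is unreadable, so nothing argues for a move beyond the scatter in either direction. Compound 4 is therefore expected to give about 22000 nM in this assay, within 11000 nM to 45000 nM. The expected step of a 1.0-fold lower number from compound 3 to compound 4 (0.00 log units; within the scatter) is estimated to lie within the scatter, with a real chance that the assay returns only a limit.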

Compound 4, half-maximal effective concentration: > 20000 nM
Compound 4 ended at the assay's limit; the forecaster's own chance of this, stated with the estimate: 50%; the middle value lies beyond the limit too.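

In this assay compound 4 gives > 20000 nM, which is a limit and not a number. The step from compound 3 to compound 4 therefore cannot be read for size. The compounds shown leave open whether compound 1, compound 2 and compound 4 differ from one another or from compound 3 on this read-out.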